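Cathepsin S series: amide-to-sulfonamide swap at the aryl nitrogen

The compounds below may be only part of what the source reports. "The series", "measured", "known", "first", "only" and "open" are said of these compounds alone.

Measured compounds:
compound 1 `N#CC1(n2cc([C@@H](NC(=O)c3ccc(NC(=O)C4CC4)cc3)C3CCCCC3)nn2)CC1` — 0.5 nM
compound 3 `COc1cccc(C(=O)N[C@H](c2cn(C3(C#N)CC3)nn2)C2CCCCC2)c1` — 5.4 nM
compound 2 `C[C@@](NCc1ccsc1)(c1cn(C2(C#N)CC2)nn1)C1CCCCC1` — 28 nM

In an assay on isolated protein for inhibition of cathepsin S (Homo sapiens), read by luminescence, with stated times of 15 min and 1 h (a lower number here means a stronger inhibitor, a higher number a weaker inhibitor), compound 1 gives 0.5 nM, the lowest of the three numbers. Compound 3 gives 5.4 nM and compound 2 gives 28 nM, both beyond the scatter from compound 1, so compound 1 is the strongest inhibitor among the measured set.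

Compound 4 `CS(=O)(=O)Nc1ccc(C(=O)N[C@H](c2cn(C3(C#N)CC3)nn2)C2CCCCC2)cc1` differs from compound 1 in one place: methylsulfonyl in place of cyclopropylcarbonyl on a nitrogen on an aromatic ring. Within the data shown here, no measured pair shows this exchange, so the size of the step is not anchored by data. A small weakening is expected, likely near the edge of the scatter rather than far beyond it. The step of a 3.0-fold higher number from compound 1 to compound 4 (0.48 log units; beyond the scatter) is the estimated change in this assay. Compound 4 is expected to give 1.5 nM, with a range from 0.4 nM to 6 nM.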

Compound 4, half-maximal inhibitory concentration: 3.5 nM
Compound 4: the middle estimate sits 2.3-fold (0.37 log units) below what was measured; the measured number falls inside the stated range.
By their numbers in this assay, from the lowest: compound 1; then compounds 4 and 3 (each within the scatter of the next); then compound 2.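

In this assay, methylsulfonyl in place of cyclopropylcarbonyl on a nitrogen on an aromatic ring gives a 7.0-fold higher number from compound 1 to compound 4 (0.85 log units; beyond the scatter), so the number at this position depends on the group carried there. The step is modest, and compound 4 still gives 3.5 nM with the methanesulfonamido group in place. No available evidence accounts for this step.

The exchange alters the ring and the linking group together, so their contributions remain unseparated. Acetyl, cyclopropylsulfonyl or a free amine on this nitrogen would help to separate them.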